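Propyl to isopropyl on the alkanoyl chain of the diacylhydrazines

The source may hold more compounds than are shown below. What is called first, only, known or untested is meant among the compounds shown, and "the series" means these compounds.

The series consists of diacylhydrazines carrying a tert-butyl group and a dimethylphenyl ring, read in an assay on cells for agonist activity at ecdysone receptor (Bombyx mori), read by a luciferase reporter, with a stated time of 24 h; on this read-out lower numbers stand for an effect already at smaller amounts and higher numbers for an effect only at larger amounts of compound. Compound 1 `CCCCCC(=O)N(NC(=O)c1cc(C)cc(C)c1)C(C)(C)C` and compound 2 `Cc1cc(C)cc(C(=O)NN(C(=O)CCC(C)C)C(C)(C)C)c1` share one core; compound 3 `CCCCCC(=O)NN(C(=O)c1cc(C)cc(C)c1)C(C)(C)C` and compound 4 `Cc1cc(C)cc(C(=O)N(NC(=O)CCC(C)C)C(C)(C)C)c1` share another. The difference between the two cores is not broken down here.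

In this assay compound 1 gives 8710 nM and compound 2 gives 14500 nM. Between them lies one change, (isopropyl in place of propyl on a saturated chain carbon, two bonds along the chain from a carbonyl carbon), and its step is a 1.7-fold higher number from compound 1 to compound 2 (0.22 log units; within the scatter). Compound 3 gives 79.4 nM in this assay; it stands lowest of the three numbers, with compound 1 and compound 2 both beyond the scatter above it.

Compound 4 has not been measured in this assay. It differs from compound 3 by isopropyl in place of propyl on a saturated chain carbon, two bonds along the chain from a carbonyl carbon, the same change that leads from compound 1 to compound 2, made at the same place. Among the measured compounds shown here, the only guide to its size is the step from compound 1 to compound 2, which lay within the scatter, so the step from compound 3 to compound 4 is expected to be of about the same size, a 1.6-fold higher number from compound 3 to compound 4 (0.21 log units; within the scatter). Whether a change measured on one core carries over to the other is not tested by anything here, so the range is kept wide. The estimate for compound 4 in this assay is 130 nM, with a range from 45 nM to 380 nM.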

Compound 4, half-maximal effective concentration: 91.2 nM
Beside the measured number, compound 4's estimate is 1.4-fold (0.15 log units) above it; low and high end bracket the measured number.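

In this assay the new step is a 1.1-fold higher number from compound 3 to compound 4 (0.06 log units; within the scatter), so on this core, as on the core of compound 1, isopropyl in place of propyl gives two numbers within the scatter of each other. Set side by side, the two steps on the two cores do not differ beyond what repeated measurements allow: the same change on two cores in this assay, a 1.7-fold higher number (0.22 log units; within the scatter) from compound 1 to compound 2 and a 1.1-fold higher number (0.06 log units; within the scatter) from compound 3 to compound 4, 1.4-fold (0.16 log units) apart, within the scatter of two such steps. This shows that, for this one change at this one place, the small step seen on one core was also seen on the other; it does not show that a change with a step beyond the scatter would carry over in the same way, and one pair on each core is no rule for the series.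

The compounds shown carry only the pentylcarbonyl and isopentylcarbonyl chains, so a longer chain such as heptanoyl, or a chain ending in an amine or a carboxylic acid, remains open on both cores. Also open, going by these compounds, is whether replacing the methyl groups on the dimethylphenyl ring with chloro or methoxy groups would give steps of the same size on the two cores.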